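The source may hold more compounds than are shown below. What is called first, only, known or untested is meant among the compounds shown, and "the series" means these compounds.

In a functional assay on WHCO1 cells (Homo sapiens) for antiproliferative activity, read by MTT assay, with a stated time of 48 h (on this read-out higher numbers stand for weaker inhibition and lower numbers for stronger inhibition), compound 1 `COc1ccc(CSSC=CC[S+]([O-])Cc2ccc(OC)cc2)cc1` gives 2100 nM, well apart from compound 2 `C=CCSS/C=C\C[S+]([O-])CCCOCc1ccc(OC)cc1` at 21000 nM. Compound 3 `C=CCSS/C=C/C[S+]([O-])CCCO` gives 27000 nM, within the usual scatter of compound 2, so compound 2 sits with compound 3 on the weaker side of this small set. The next compound, compound 4 `C=CCSS/C=C/C[S+]([O-])CCCOCc1ccc(OC)cc1`, differs from compound 2 only in shape: the two compounds have the same atoms and bonds; at least one stereo element is drawn with a configuration in one of them and without one in the other: 1 of 2 stereo elements differ; a double bond is drawn Z in compound 2 and E in compound 4; a double bond is drawn Z in compound 2 and E in compound 4. For the measured compounds named here, no measured pair isolates this switch, but compound 3, which also has the E form, gives 27000 nM. No change beyond the scatter is expected, in either direction, so the estimated step is small: a 1.1-fold lower number from compound 2 to compound 4 (0.02 log units; within the scatter). For compound 4 the estimated value is 20000 nM, with an expected range of 9000 nM to 42000 nM.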

Compound 4, half-maximal inhibitory concentration: 18000 nM
Compound 4: the middle estimate sits 1.1-fold (0.05 log units) above what was measured; the measured number falls inside the stated range.
By their numbers in this assay, from the lowest: compound 1; then compounds 4, 2 and 3 (each within the scatter of the next).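

For the compounds shown here, compounds 2 and 4 form the first measured pair that isolates the switch of this double bond from Z to E. In this assay the result is a 1.2-fold lower number from compound 2 to compound 4 (0.07 log units; within the scatter) and so this switch, on its own, leaves no difference that can be told from the scatter. One caution applies to this comparison: the fact that one of compounds 2 and 4 is drawn with a defined configuration and the other without, at the place where they differ.

Left open is whether the switch stays as small in compounds that carry an amine or a carboxylic acid, or a longer chain, on the shared core.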